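The source may report more compounds than this note shows. Statements on the series, on what has been measured and on what is new or still open speak of the compounds shown alone.

Of the compounds shown here, three built on one shared core have been tested in an ADME assay on RAW264.7 cells (Mus musculus) for cytotoxicity, read by MTT assay, with a stated time of 48 h, tested at 50 uM; on this read-out higher numbers stand for more inhibition at the one concentration tested (going by the name of the read-out) and lower numbers for less inhibition. Compound 1 `N=C1S/C(=C\c2ccc(OCc3ccccc3)cc2)C(=O)N1c1ccccc1[N+](=O)[O-]` gives 24.4%, compound 2 `N=C1S/C(=C\c2ccc(OCc3ccccc3)cc2)C(=O)N1c1cccc([N+](=O)[O-])c1` gives 52.9%, and compound 3 `N=C1S/C(=C\c2ccc(OCc3ccccc3)cc2)C(=O)N1c1ccc(Cl)cc1Cl` gives 13.8%. Compound 3 therefore stands lowest of the three numbers: its nearest neighbour is compound 1, and compound 2 lies furthest from it. Every difference among these three concerns the group on the amide-type nitrogen in the ring, and each swap moved the read-out beyond the scatter: a number 28.5 percentage points higher from compound 1 to compound 2 (beyond the scatter), a number 10.6 percentage points lower from compound 1 to compound 3 (beyond the scatter) and a number 39.1 percentage points lower from compound 2 to compound 3 (beyond the scatter).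

Compound 4 `Cc1c(Cl)cccc1N1C(=N)S/C(=C\c2ccc(OCc3ccccc3)cc2)C1=O` has not yet been measured in this assay. It differs from compound 3 by 3-chloro-2-methylphenyl in place of 2,4-dichlorophenyl on an amide-type nitrogen in a ring. Within the data shown here, no measured pair exchanges a 2,4-dichlorophenyl for a 3-chloro-2-methylphenyl, so the step cannot be read off directly. The measured swaps at this position ranged from modest to large, so a shift beyond the scatter is plausible in either direction; since compound 3 already sits lowest, the room downward is limited, and a modest rise seems the more likely outcome. The step expected from this change is a number 8.2 percentage points higher from compound 3 to compound 4 (within the scatter). For compound 4 the estimate in this assay is 22%, with a range from 6% to 42%.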

Compound 4, a percentage reported as inhibition, at one concentration (the size of the read-out at that concentration, not a potency): 59.7%
Compound 4: middle estimate off by 37.7 percentage points, on the low side; measured number above the stated range.
By their numbers in this assay, from the lowest: compound 3; then compound 1; then compounds 2 and 4 (each within the scatter of the next).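

Replacing the 2,4-dichlorophenyl with 3-chloro-2-methylphenyl on the amide-type nitrogen gives a number 45.9 percentage points higher from compound 3 to compound 4 (beyond the scatter) in this assay, so carrying chlorine on this phenyl ring does not by itself keep the number low. The nitro-bearing compounds add to the picture: the comparison with the 2-nitrophenyl group gives a number 35.3 percentage points higher from compound 1 to compound 4 (beyond the scatter), whereas the comparison with the 3-nitrophenyl group gives a number 6.8 percentage points higher from compound 2 to compound 4 (within the scatter), so two quite different groups cannot be told apart here. Among these compounds, no independent measurement bears on why this exchange of groups with equal heavy-atom counts moves the number so far.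

Every group shown at this position is a substituted phenyl ring, so it remains open how a plain phenyl, a phenyl carrying a methoxy group or a carboxylic acid, or a saturated ring such as cyclohexyl would read. Also open, from the compounds shown here alone, is whether the methyl group or the chlorine in its new place carries the step, which 2-methylphenyl and 3-chlorophenyl groups at this position could begin to separate.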